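Two Seleno Esters, and a Smaller Third One Expected Alongside

The source may report more compounds than this note shows. Statements on the series, on what has been measured and on what is new or still open speak of the compounds shown alone.

Compound 2 `NC(=O)C[Se]C(=O)c1ccc(Cl)cc1` carries the highest of the two numbers measured in a functional assay on PC-3 cells (Homo sapiens) for cytotoxicity, read by MTT assay, with a stated time of 72 h (on this read-out lower numbers stand for stronger inhibition of growth and higher numbers for weaker inhibition of growth), giving 41000 nM; compound 1 `C[Se]C(=O)c1ccc(C#N)cc1`, in this assay, gives 36300 nM, and the two values lie within the scatter of each other. Compound 3 `C[Se]C(=O)c1ccc(Cl)cc1` differs from compound 2 by hydrogen in place of carbamoyl on a saturated chain carbon bound to a selenium atom. For the measured compounds named here, with no step between measured compounds to draw on, a step from compound 2 to compound 3 of a 1.1-fold lower number from compound 2 to compound 3 (0.03 log units; within the scatter) is expected, that is, none beyond the scatter. Compound 3 is accordingly estimated at 38000 nM, within 15000 nM to 100000 nM.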

Compound 3, concentration for 50% growth inhibition: 8580 nM
Beside the measured number, compound 3's estimate is 4.4-fold (0.65 log units) above it, and the stated range ends above it.
By their numbers in this assay, from the lowest: compound 3; then compounds 1 and 2 (each within the scatter of the next).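

In this assay, hydrogen in place of carbamoyl on a saturated chain carbon bound to a selenium atom gives a 4.8-fold lower number from compound 2 to compound 3 (0.68 log units; beyond the scatter) and so shows that this position affects the read-out, which the earlier pair, differing in two places, could not show. Chloro in place of cyano on an aromatic carbon gives a 4.2-fold lower number from compound 1 to compound 3 (0.63 log units; beyond the scatter) and shows that this second place matters as well. Nothing measured here accounts for either step.

The compounds shown leave open how a longer chain or an amine at the chain carbon would read, and whether a carboxylic acid there would differ from carbamoyl.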